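Para-group exchange on the pendant phenyl, compounds 1 to 4

The source may report more compounds than this note shows. Statements on the series, on what has been measured and on what is new or still open speak of the compounds shown alone.

Measured so far:
compound 1 `COc1ccc(CN2C(=O)C(=O)c3cc(-c4cc(OC)cc(OC)c4)ccc32)cc1` — 510 nM
compound 2 `COc1ccc(CN2C(=O)C(=O)c3cc(-c4ccc(Cl)cc4)ccc32)cc1` — 230 nM
compound 3 `COc1ccc(CN2C(=O)C(=O)c3cc(-c4ccc(OC(C)C)cc4)ccc32)cc1` — 310 nM

All three share one core and differ only in the pendant phenyl ring. In a functional assay on K562 cells (Homo sapiens) for antiproliferative activity, read by MTT assay, with a stated time of 48 h (on this read-out higher numbers stand for weaker inhibition and lower numbers for stronger inhibition), compound 3 stands second highest of the three numbers. Its nearest neighbour is compound 2, with a 1.3-fold higher number from compound 2 to compound 3 (0.13 log units; within the scatter); the furthest step is a 1.6-fold lower number from compound 1 to compound 3 (0.22 log units; within the scatter). Neither separates compound 3 from the others.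

Compound 4 `COc1ccc(CN2C(=O)C(=O)c3cc(-c4ccc(C#N)cc4)ccc32)cc1` is the next member. The change from compound 3 is cyano in place of isopropoxy on an aromatic carbon.

Among the measured compounds shown here, of the measured steps, only one exchanges a single group on the pendant phenyl while the rest stays fixed: a 1.3-fold higher number from compound 2 to compound 3 (0.13 log units; within the scatter). The other two, a 2.2-fold lower number from compound 1 to compound 2 (0.35 log units; beyond the scatter) and a 1.6-fold lower number from compound 1 to compound 3 (0.22 log units; within the scatter), replace the whole substituted phenyl and are less direct guides; only the first of them lies beyond the scatter. A cyano group has not been measured in this series, so its effect is not known from these compounds. Taken together the single-group exchange seen so far suggests little movement, and compound 4 is expected to give 300 nM in this assay, with a range of 140 nM to 650 nM. This estimate means a 1.0-fold lower number from compound 3 to compound 4 (0.01 log units; within the scatter), a step expected to stay within the scatter.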

Compound 4, half-maximal inhibitory concentration: 260 nM
The estimate for compound 4 lay 1.2-fold (0.06 log units) above the measured number; low and high end bracket the measured number.
By their numbers in this assay, from the lowest: compounds 2, 4, 3 and 1 (each within the scatter of the next, the first and the last beyond it).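

In this assay, cyano on the aromatic carbon para to a large group does not separate from either group measured there before: a 1.2-fold lower number from compound 3 to compound 4 (0.08 log units; within the scatter), and a 1.1-fold higher number from compound 2 to compound 4 (0.05 log units; within the scatter). The single-group exchanges at this position now cover chloro, isopropoxy and cyano, and all of them stay within the scatter, so the number does not distinguish these three groups in compounds 2, 3 and 4. Replacing the whole ring gives a 2.0-fold lower number from compound 1 to compound 4 (0.29 log units; within the scatter), which stays within the scatter, whereas the corresponding step to the 4-chlorophenyl compound, a 2.2-fold lower number from compound 1 to compound 2 (0.35 log units; beyond the scatter), lies beyond it, so only compound 2 is separated from compound 1, and only narrowly. No measurement available here offers an explanation for these numbers.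

Still open, as far as these compounds go, is whether an amine, a carboxylic acid or a longer alkoxy chain on the same carbon would move the number beyond the scatter. The compounds shown also leave open whether chloro, isopropoxy and cyano would remain indistinguishable on a core changed elsewhere.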